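The source may report more compounds than this note shows. Statements on the series, on what has been measured and on what is new or still open speak of the compounds shown alone.

Compound 1 `CC(C)c1ccc(Nc2nc(Nc3ccc(N4CCN(C)CC4)cn3)ncc2Cl)cc1`: 13700 nM
Compound 2 `CN1CCN(c2ccc(Nc3ncc(Cl)c(Nc4ccc(C(C)(C)C)cc4)n3)nc2)CC1`: 6070 nM

In an ADME assay on L02 cells (Homo sapiens) for inhibition, read by CCK-8 assay, with a stated time of 48 h (on this read-out lower numbers stand for stronger inhibition of growth and higher numbers for weaker inhibition of growth), compound 2 has the lower of the two numbers, at 6070 nM. Compound 3 `Cc1cc(C)c(Nc2nc(Nc3ccc(N4CCN(C)CC4)cn3)ncc2Cl)c(C)c1` carries 2,4,6-trimethylphenyl in place of 4-(tert-butyl)phenyl on a nitrogen on an aromatic ring. Going by the values given here, only one measured step bears on this: a 2.3-fold lower number from compound 1 to compound 2 (0.35 log units; beyond the scatter), a modest change made within the group that leaves here. With so little evidence, a similarly modest move back toward a higher number is expected, meaning weaker inhibition of growth. The expected step is a 1.6-fold higher number from compound 2 to compound 3 (0.22 log units; within the scatter). For compound 3 the estimated value is 10000 nM, with an expected range of 4000 nM to 25000 nM.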

Compound 3, concentration for 50% growth inhibition: 20500 nM
Beside the measured number, compound 3's estimate is 2.1-fold (0.31 log units) below it; the measured number falls inside the stated range.
By their numbers in this assay, from the lowest: compound 2; then compounds 1 and 3 (each within the scatter of the next).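

In this assay, 2,4,6-trimethylphenyl in place of 4-(tert-butyl)phenyl gives a 3.4-fold higher number from compound 2 to compound 3 (0.53 log units; beyond the scatter), so this nitrogen substituent can shift the number through more than a single added methyl on the chain. Against 4-isopropylphenyl, the same group gives a 1.5-fold higher number from compound 1 to compound 3 (0.18 log units; within the scatter), which leaves these two groups unresolved and only compound 2 apart from both. Nothing available here explains the shift.

From the compounds shown here alone, it remains open how this number would respond to a phenyl ring carrying an amine or a carboxylic acid. A longer chain in place of tert-butyl is equally untested among the compounds shown.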